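Ethyl for methoxy on the aryl arm of compound 1

This account rests on a few compounds, and the source may have more. Where it says the series, first, only, none or still open, it means among the compounds named here.

For the measured compounds named here, compound 1 `COc1cccc(C(Nc2ccccn2)c2ccc3cccnc3c2O)c1` is one of two compounds measured in an assay for inhibition of protein disulfide-isomerase (Homo sapiens), with a stated time of 1 h; on this read-out higher numbers stand for weaker inhibition and lower numbers for stronger inhibition. In this assay compound 1 gives 2860 nM, the higher of the two numbers; compound 2 `COc1cc(C(Nc2ccc(C)cn2)c2ccc3cccnc3c2O)cc(OC)c1O` gives 180 nM, a gap between the two that lies beyond the usual scatter. Going by the values given here, no step between measured compounds that differ in one place is available, so the effect of a single change on this scaffold is not yet fixed by the data.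

Compound 3 `CCc1ccc(C(Nc2ccccn2)c2ccc3cccnc3c2O)cc1` differs from compound 1 in one place: 4-ethylphenyl in place of 3-methoxyphenyl on a saturated chain carbon bound to an aromatic carbon and a nitrogen on an aromatic ring. Both groups are of the same size, but the hydrogen-bond acceptor of the methoxy group is lost. Among the compounds with values here, with no comparable step to draw on, the expected step from compound 1 to compound 3 is a 1.2-fold higher number from compound 1 to compound 3 (0.09 log units; within the scatter), which would lie within the scatter of compound 1's own value. Compound 3 is therefore estimated at 3500 nM, with a range from 1200 nM to 10000 nM.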

Compound 3, half-maximal inhibitory concentration: 170 nM
Compound 3: middle estimate off by 21-fold (1.31 log units), on the high side, and the stated range ends above it.
By their numbers in this assay, from the lowest: compounds 3 and 2 (each within the scatter of the next); then compound 1.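

In this assay, the aryl arm on the saturated chain carbon now has a single-change step on this scaffold: 4-ethylphenyl in place of 3-methoxyphenyl gives a 17-fold lower number from compound 1 to compound 3 (1.23 log units; beyond the scatter) on an otherwise unchanged core. This position therefore responds strongly to the change, and the lower number of compound 3 is reached without the methoxy group and with no hydrogen-bond acceptor on this arm. No measurement bearing on the origin of this step is at hand.

The step changes both the group and its number in the name, so the shown compounds do not separate the swap of methoxy for ethyl from the change of ring position. Still open, as far as these compounds go, are 4-methoxyphenyl and 3-ethylphenyl, which would split the two, and whether a longer chain such as 4-propylphenyl or an amine such as 4-aminophenyl is accepted on this arm.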